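Terminal amine variation on the side chain: notes toward compound 4

The source may hold more compounds than are shown below. What is called first, only, known or untested is meant among the compounds shown, and "the series" means these compounds.

The series keeps one shared core and changes only the amine at the end of the side chain. In a functional assay on A549 cells (Homo sapiens) for antiproliferative activity, read by MTT assay, with a stated time of 72 h (a higher number here means a weaker inhibitor, a lower number a stronger inhibitor), compound 1 `COc1cc2c(Nc3ccc(C#N)cc3)ncnc2cc1OCCCN(C)C` gives 60500 nM, the higher of the two numbers available, with compound 3 nearest. Compound 3 `COc1cc2c(Nc3ccc(C#N)cc3)ncnc2cc1OCCCN1CCC(N2CCCCC2)CC1` gives 30700 nM in this assay, and the step of a 2.0-fold lower number from compound 1 to compound 3 (0.29 log units; within the scatter) remains within the scatter. Compound 2 `COc1cc2c(Nc3ccc(C#N)cc3)ncnc2cc1OCCCN1CCc2ccccc2C1` reaches only a limit in this assay, > 100000 nM, which is not a number; (the limit of > 100000 nM in this assay, at which 1 of the 3 values shown sits). The step of an at least 1.6-fold higher number from compound 1 to compound 2 (0.21 log units; that floor lies within the scatter) has a floor inside the scatter and so settles nothing, whereas an at least 3.2-fold lower number from compound 2 to compound 3 (0.51 log units; beyond the scatter) is beyond the scatter.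

Compound 4 `COc1cc2c(Nc3ccc(C#N)cc3)ncnc2cc1OCCCN1CCN(c2ccncc2)CC1` awaits measurement in this assay. It differs from compound 1 by 4-(pyridin-4-yl)piperazin-1-yl in place of dimethylamino on a saturated chain carbon, three bonds along the chain from an oxygen on an aromatic ring. The two cyclic replacements already measured bear on it: one moved the number no further than the scatter, the other ran past the upper limit. No clear direction follows, and the expected step of a 1.0-fold lower number from compound 1 to compound 4 (0.00 log units; within the scatter) is therefore close to none. Compound 4 is expected near 60000 nM, between 25000 nM and 150000 nM.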

Compound 4, half-maximal inhibitory concentration: 25500 nM
For compound 4 the middle estimate is 2.4-fold (0.37 log units) above the measured one; low and high end bracket the measured number.
By their numbers in this assay, from the lowest: compounds 4, 3 and 1 (each within the scatter of the next, the first and the last beyond it). At a limit, above all of these: compound 2.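

In this assay, going by these compounds alone, the step of a 2.4-fold lower number from compound 1 to compound 4 (0.38 log units; beyond the scatter) is the first replacement of dimethylamino at this chain end to pass beyond the scatter, so a large cyclic amine can lower the number here. The step of a 1.2-fold lower number from compound 3 to compound 4 (0.08 log units; within the scatter) stays within the scatter, so 4-(pyridin-4-yl)piperazin-1-yl and 4-(piperidin-1-yl)piperidin-1-yl cannot be told apart, while the step of an at least 3.9-fold lower number from compound 2 to compound 4 (0.59 log units; beyond the scatter) sets 1,2,3,4-tetrahydroisoquinolin-2-yl apart from the former. Compound 2 goes against any rule that a cyclic amine alone lowers the number, though it stands only at a limit, which is not a number: the limit of > 100000 nM in this assay, at which 1 of the 4 values shown sits.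

Open, from the compounds shown here alone, is whether the pyridine ring nitrogen matters, which a 4-phenylpiperazin-1-yl group would test. Also open, going by these compounds, is whether a morpholine at the chain end or a longer chain would move the number.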